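A few compounds are considered here, and "the series" means these few. Any claim that something is new, unique, unknown or untested is made for them only; others in the source may bear on it.

Compound 1 has the structure `Clc1[nH]ccc2ncnc1-2`. In a functional assay on EL4 cells (Mus musculus) for inhibition, tested at 100 uM (a higher number here means more inhibition at the concentration tested (going by the name of the read-out), a lower number less inhibition), compound 1 gives < 5%, which is a limit of the assay rather than a number. Going by the values given here, compound 2, `OC[C@H]1OC(n2cnc3c(S)nccc32)[C@H](O)[C@@H]1O`, is the only other compound measured. In this assay compound 2 also gives < 5%, again a limit. Both values sit at the same place: the limit of < 5% in this assay, at which 2 of the 2 values shown sit. Compound 1 therefore stands at the floor of what this assay can report, and no measured neighbour sets a step against it. Compound 3, `CN(C)c1[nH]ccc2ncnc1-2`, has not been measured yet. It differs from compound 1 in one place: dimethylamino in place of chloro on an aromatic carbon. Among the compounds with values here, with no measured step to lean on, the expectation for compound 3 is no change beyond the scatter, and the step that the limit leaves unreadable from compound 1 to compound 3 is estimated accordingly. Compound 3 is expected to give about 4% in this assay, within a range from 0% to 15%.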

Compound 3, a percentage reported as inhibition, at one concentration (the size of the read-out at that concentration, not a potency): 25%
Compound 3: middle estimate off by 21 percentage points, on the low side, and the stated range ends below it.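

In this assay, this aromatic carbon next to the ring nitrogen proves sensitive to what it carries: exchanging chloro for dimethylamino gives a number at least 20 percentage points higher from compound 1 to compound 3 (beyond the scatter). Going by these compounds alone, until now, every measured compound sat at the limit, so nothing showed that the read-out could move at all on this core; compound 3 is the first to give a true number. The step has only a lower bound, though, and the true size stays hidden since the starting point is a limit: the limit of < 5% in this assay, at which 2 of the 3 values shown sit.

The compounds shown cannot say whether the ring-bound nitrogen or its two methyl groups matter more, a question that a plain amine or a longer chain on that nitrogen would address. A single read-out at one concentration also leaves the potency of compound 3 unknown.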